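The source may hold more compounds than are shown below. What is called first, only, known or untested is meant among the compounds shown, and "the series" means these compounds.

The series shares one core, seen in compound 1 `CC(C)n1ncc2c(C(=O)NCc3cn(-c4cccc(F)c4)nn3)cccc21`, compound 2 `CC(C)n1ncc2c(C(=O)NCc3cn(-c4ccc([N+](=O)[O-])cc4)nn3)cccc21` and compound 3 `Cc1ccc(-n2cc(CNC(=O)c3cccc4c3cnn4C(C)C)nn2)cc1`. In a functional assay on HepG2 cells (Homo sapiens) for inhibition, read by MTT assay, with a stated time of 72 h (on this read-out higher numbers stand for weaker inhibition and lower numbers for stronger inhibition), compound 1 gives only a limit of > 40000 nM. Compound 2 likewise gives only a limit of > 40000 nM. Compound 3 too gives only a limit of > 40000 nM. The step that the two limits leave unreadable from compound 1 to compound 2, the step that the two limits leave unreadable from compound 1 to compound 3 and the step that the two limits leave unreadable from compound 2 to compound 3 cannot be read in size because every value shown sits at the limit of > 40000 nM in this assay, at which 3 of the 3 values shown sit. Compound 3 thus stands exactly where the other two stand, with a limit and no number of its own. Compound 4 `CCc1ccc(-n2cc(CNC(=O)c3cccc4c3cnn4C(C)C)nn2)cc1` differs from compound 3 by methyl in place of hydrogen on a saturated chain carbon bound to an aromatic carbon. For the measured compounds named here, no measured step bears directly on this change, and the three steps among compounds 1, 2 and 3 offer no readable size to lean on. From compound 3 to compound 4 a step of a number no higher from compound 3 to compound 4 (the limit leaves the size open) is expected, which is to say none that the assay could resolve. Compound 4 is therefore expected to give about 40000 nM, with a range of 15000 nM to 120000 nM, most probably again as a limit rather than a number.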

Compound 4, half-maximal inhibitory concentration: > 40000 nM
Compound 4 was reported as a limit (the forecaster's own chance of this, stated with the estimate: 85%); the middle value sits exactly at the limit.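

Compound 4 also gives only a limit, so its steps from compound 1, compound 2 and compound 3 cannot be read in size, because all the values shown sit at the same point: the limit of > 40000 nM in this assay, at which 4 of the 4 values shown sit.

The compounds shown leave open whether any group on the shared core would give a number rather than a limit in this assay.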